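Aryl swap on the triazole series: compound 3 to compound 4

The compounds below may be only part of what the source reports. "The series", "measured", "known", "first", "only" and "open" are said of these compounds alone.

Values in a functional assay on A549 cells (Homo sapiens) for inhibition, read by MTT assay, with a stated time of 24 h (on this read-out higher numbers stand for weaker inhibition and lower numbers for stronger inhibition), so far:
compound 1 `CC1(C)[C@H]2CC[C@]1(C)N(Cc1cn(-c3ccc(F)cc3)nn1)C(=O)C2` gives 230 nM
compound 2 `CC1(C)[C@H]2CC[C@]1(C)N(Cc1cn(-c3cccc(Cl)c3)nn1)C(=O)C2` gives 60 nM
compound 3 `CC1(C)[C@H]2CC[C@]1(C)N(Cc1cn(-c3ccc(Br)cc3)nn1)C(=O)C2` gives 80 nM
compound 4 `COc1cccc(-n2cc(CN3C(=O)C[C@@H]4CC[C@@]3(C)C4(C)C)nn2)c1` has no value yet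

Compound 3 stands level with compound 2 at the low end of the three numbers: a 1.3-fold higher number from compound 2 to compound 3 (0.12 log units; within the scatter) and so gives no order between them. The remaining compound is clearly apart, with a 2.9-fold lower number from compound 1 to compound 3 (0.46 log units; beyond the scatter) on record.

The next change is 3-methoxyphenyl in place of 4-bromophenyl on an aromatic nitrogen and it places 3-methoxyphenyl in place of 4-bromophenyl on an aromatic nitrogen, with the shared core untouched. Within the data shown here, no compound measured so far carries this group, so no step reports the change directly.

The closest evidence is the set of aryl swaps already measured. Two were modest, a 3.8-fold lower number from compound 1 to compound 2 (0.58 log units; beyond the scatter) and a 2.9-fold lower number from compound 1 to compound 3 (0.46 log units; beyond the scatter) as well, and the 3-chlorophenyl of compound 2 is the nearest named group, at 60 nM in this series. Compound 1 at 230 nM shows that not every aryl group keeps the low number, so the expectation leans slightly upward.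

The expected move is a 1.4-fold higher number from compound 3 to compound 4 (0.14 log units; within the scatter) and no clear change is therefore anticipated. For compound 4 the estimate is 110 nM with an expected range from 40 nM to 300 nM in this assay when measured.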

Compound 4, half-maximal inhibitory concentration: 240 nM
For compound 4 the middle estimate is 2.2-fold (0.34 log units) below the measured one; the measured number falls inside the stated range.
By their numbers in this assay, from the lowest: compounds 2 and 3 (each within the scatter of the next); then compounds 1 and 4 (each within the scatter of the next).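

In this assay, among these compounds, 3-methoxyphenyl is the only aryl group so far on this aromatic nitrogen that carries oxygen, and it does not stay with the lower pair of numbers, either against 4-bromophenyl (a 3.0-fold higher number from compound 3 to compound 4 (0.48 log units; beyond the scatter)) or against 3-chlorophenyl (a 4.0-fold higher number from compound 2 to compound 4 (0.60 log units; beyond the scatter)). The second step is the tighter comparison, since only chloro gives way to methoxy on an aromatic carbon, so the shared 3-substituted phenyl pattern does not by itself keep the number low in these compounds. The step to the 4-fluorophenyl compound (a 1.0-fold higher number from compound 1 to compound 4 (0.02 log units; within the scatter)) gives no order between those two aryl groups, so the four compounds fall into two levels, with compound 2 and compound 3 at the lower one and compound 1 and compound 4 at the higher; no measurement on hand accounts for this split.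

The compounds shown leave group and place tangled, and the pairs 3-bromophenyl with 4-chlorophenyl and 3-fluorophenyl with 4-methoxyphenyl would separate the identity of the substituent from where it sits on the phenyl ring. Also open, from the compounds shown here alone, is how an unsubstituted phenyl, or a phenyl bearing an amine or a carboxylic acid, would read against these two levels.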